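The compounds below may be only part of what the source reports. "The series", "measured", "known", "first", "only" and "open" are said of these compounds alone.

Compound 1, `COc1ccc(CS(=O)(=O)/C=C/c2ccccc2OC)cc1`, is the reference point of this small set. In a functional assay on H157 cells (Homo sapiens) for antiproliferative activity, read by trypan blue exclusion (a higher number here means a weaker inhibitor, a lower number a stronger inhibitor), compound 1 gives 5000 nM. Compound 2, `COc1ccc(CS(=O)(=O)/C=C/c2cc(OC)ccc2OC)cc1`, carries one more group on the core. In this assay compound 2 reaches only a limit of the assay, > 20000 nM. The change from compound 1 to compound 2 is methoxy in place of hydrogen on an aromatic carbon, and it produced an at least 4.0-fold higher number from compound 1 to compound 2 (0.60 log units; beyond the scatter).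

Compound 3, `COc1ccc(CS(=O)(=O)/C=C/c2cc(OC)cc(OC)c2)cc1`, has a different substitution pattern on the same core; the difference between the core of compound 1 and that of compound 3 is not broken down here. In this assay compound 3 likewise gives only a limit, > 20000 nM.

Compound 4, `COc1ccc(CS(=O)(=O)/C=C/c2cc(OC)c(OC)c(OC)c2)cc1`, has not yet been measured. It differs from compound 3 by methoxy in place of hydrogen on an aromatic carbon. Among the compounds with values here, this is the same kind of change as the one from compound 1 to compound 2, but the surroundings differ: in compound 2 the entering methoxy sits meta to a large group and para to a methoxy group, whereas in compound 4 it sits ortho to two methoxy groups and para to a large group.

Compound 3 already stands at the limit of > 20000 nM in this assay, at which 2 of the 3 values shown sit, and the earlier step moved the value in that same direction, so compound 4 is expected to stay at or beyond it, with an estimated step that the limit leaves unreadable from compound 3 to compound 4. The estimate for compound 4 in this assay is therefore 25000 nM, in a range from 8000 nM to 60000 nM.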

Compound 4, half-maximal inhibitory concentration: > 20000 nM
Compound 4 gave a limit, no number; the forecaster's own chance of this, stated with the estimate: 70%; the middle value lies beyond the limit too.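

Compound 4 gives > 20000 nM in this assay, which is a limit of the assay and not a number. Compound 3 also stands at a limit, so no step can be read from compound 3 to compound 4. The compounds shown leave open how far compound 2, compound 3 and compound 4 lie beyond that limit, and whether the added methoxy changes the activity of compound 3 at all.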